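Phenyl in place of methoxy: working notes on cytotoxicity

A few compounds are considered here, and "the series" means these few. Any claim that something is new, unique, unknown or untested is made for them only; others in the source may bear on it.

Of the compounds shown here, two have been measured so far in an ADME assay on L929 cells (Mus musculus) for cytotoxicity, read by resazurin assay, with a stated time of 96 h; on this read-out higher numbers stand for lower toxicity in this test and lower numbers for higher toxicity in this test. There, compound 1 `COc1cccc(OC/C(=N\NC(N)=S)c2ccc(Br)cc2)c1` gives 50700 nM, and compound 2 `COc1ccc(OC/C(=N\NC(N)=S)c2ccc(Br)cc2)cc1` gives 102000 nM. These two values lie within the scatter of each other, so they do not separate the compounds. Compound 2 is the starting point for the next comparison.

Compound 3 `NC(=S)N/N=C(\COc1ccc(-c2ccccc2)cc1)c1ccc(Br)cc1` is not yet measured in this assay. It differs from compound 2 by phenyl in place of methoxy on an aromatic carbon, which places phenyl in place of methoxy on an aromatic carbon, para to a large group. Within the data shown here, no measured pair shows what a change of this kind does, so any expectation here is a judgement with a wide margin. A moderate step beyond the scatter is expected, towards a lower number and so towards higher toxicity in this test. The estimated change is a 2.9-fold lower number from compound 2 to compound 3 (0.46 log units; beyond the scatter). The expected value for compound 3 is 35000 nM, with an estimated range of 10000 nM to 110000 nM.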

Compound 3, half-maximal cytotoxic concentration: 90800 nM
The estimate for compound 3 lay 2.6-fold (0.41 log units) below the measured number, and the stated range covers the measured number.
By their numbers in this assay, from the lowest: compounds 1, 3 and 2 (each within the scatter of the next).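

In this assay, the step at this position is small: a 1.1-fold lower number from compound 2 to compound 3 (0.05 log units; within the scatter), so compound 2 and compound 3 are not separated. Among these compounds, this is the first reading of this change. On an aromatic carbon, para to a large group, a methoxy of 2 heavy atoms with 1 hydrogen-bond acceptor gives way to a phenyl of 6 heavy atoms with no acceptor, and the read-out does not move beyond the scatter. The finding rests on this single pair, and nothing measured accounts for the outcome in either direction.

The compounds shown leave open whether this tolerance extends to other groups on the same carbon, such as an amine, a carboxylic acid or a longer alkoxy chain, any of which could still separate from compound 2 in this test. Among the compounds shown here, it also remains open whether a substituted phenyl, for example one carrying a fluorine or a hydroxyl group, would stay within the scatter of compound 3 or would give the first step at this position that lies beyond it.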